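Adding a Chloro Group to a Weak Sulfonamide Triazole

The source may report more compounds than this note shows. Statements on the series, on what has been measured and on what is new or still open speak of the compounds shown alone.

Compound 1, `O=c1[nH]cc(S(=O)(=O)Nc2ccccc2-c2cn(-c3ccccc3)nn2)c(=O)[nH]1`, gives 6790 nM in a functional assay on A549 cells (Homo sapiens) for antiproliferative activity, read by MTT assay, with a stated time of 24 h; on this read-out lower numbers stand for stronger inhibition and higher numbers for weaker inhibition.
Compound 2, `Cc1ccc(-n2cc(-c3ccccc3NS(=O)(=O)c3c[nH]c(=O)[nH]c3=O)nn2)cc1`, gives 2910 nM in this assay.
Compound 3, `O=c1[nH]cc(S(=O)(=O)Nc2cccc(-c3cn(-c4ccccc4)nn3)c2)c(=O)[nH]1`, gives 12700 nM in this assay.

All three share the same core, and all three are weak in this assay. Compound 3 has the highest number of the three: its gap to compound 1 is within the usual scatter of repeated measurements, while its gap to compound 2 is beyond it, so compound 3 does stand apart from compound 2.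

Compound 4, `O=c1[nH]cc(S(=O)(=O)Nc2cccc(-c3cn(-c4ccc(Cl)cc4)nn3)c2)c(=O)[nH]1`, has not yet been measured. It differs from compound 3 by chloro in place of hydrogen on an aromatic carbon. Going by the values given here, only one measured step resembles this change: a 2.3-fold lower number from compound 1 to compound 2 (0.37 log units; beyond the scatter), where a small group was likewise added to an aromatic carbon of the phenyl ring on the triazole. That step was modest but beyond the scatter. Taking it as the nearest guide, a lowering of similar size is expected for compound 4, although a single step is a thin basis and the change here is chloro rather than methyl.

Compound 4 is therefore expected to give 6000 nM in this assay, with a range from 2500 nM to 15000 nM. This estimate corresponds to an expected step of a 2.1-fold lower number from compound 3 to compound 4 (0.33 log units; beyond the scatter).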

Compound 4, half-maximal inhibitory concentration: 1730 nM
Beside the measured number, compound 4's estimate is 3.5-fold (0.54 log units) above it; the measured number lies below the stated range.
By their numbers in this assay, from the lowest: compounds 4 and 2 (each within the scatter of the next); then compounds 1 and 3 (each within the scatter of the next).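

In this assay the change from phenyl to 4-chlorophenyl, a single chlorine atom on an aromatic carbon para to a large group, gives a 7.3-fold lower number from compound 3 to compound 4 (0.87 log units; beyond the scatter) and so shows that the number of compound 3 can be moved well beyond the scatter by one added atom on this outer ring. Going by these compounds alone, until now the only step on that ring was the methyl change on a different parent, a 2.3-fold lower number from compound 1 to compound 2 (0.37 log units; beyond the scatter) and the new result shows that this ring also responds to substitution when the sulfonamide and triazole are attached as in compound 3. Nothing available here gives a measured reason for the size of the new step.

The two steps differ in both the added group and the parent, so the compounds shown cannot separate the contribution of chloro from that of the parent, and it remains open what chloro would do on compound 1 or methyl on compound 3. Also open, from the compounds shown here alone, is how fluoro, bromo, methoxy, an amine or a carboxylic acid would compare on the same carbon, and whether chloro elsewhere on this ring would give a similar step.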